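A Second Fluorine and the Amine Oxidase Read-out

The source may report more compounds than this note shows. Statements on the series, on what has been measured and on what is new or still open speak of the compounds shown alone.

Compounds measured so far:
Compound 1, `N#Cc1ccc(-c2csc(N/N=C\c3cccnc3)n2)cc1`, gives 40%.
Compound 2, `Fc1ccc(-c2csc(N/N=C\c3cccnc3)n2)cc1`, gives 40%.
Compound 3, `Fc1ccc(-c2csc(N/N=C\c3ccncc3)n2)cc1`, gives 40%.

All three values come from an in vitro assay on BTI-TN-5B1-4 cells for inhibition of Amine oxidase [flavin-containing] A (Homo sapiens), read by Amplex Red, with a stated time of 15 min, tested at 100 uM; a lower number here means less inhibition, a higher number more inhibition at the concentration tested (going by the name of the read-out). Compound 2 stands level with compounds 1 and 3 in this assay; the gaps to both lie within the scatter, so no order among the three can be read from these numbers. Compound 4, `Fc1ccc(-c2csc(N/N=C\c3cccnc3)n2)c(F)c1`, has not yet been measured. It differs from compound 2 as follows: fluoro in place of hydrogen on an aromatic carbon.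

For the measured compounds named here, two measured steps bear on this change, both of them also single replacements on the same shared core. The step of no change at the digits printed from compound 1 to compound 2 (within the scatter) and the step of no change at the digits printed from compound 2 to compound 3 (within the scatter) were each within the scatter. On that record the change from compound 2 to compound 4 is expected to be of the same kind, and the step of no change at the digits printed from compound 2 to compound 4 (within the scatter) is expected to stay within the scatter. Compound 4 is therefore estimated to give 40%, with a range from 25% to 55%, because compound 2 gives 40% and neither prior step moved the read-out.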

Compound 4, a percentage reported as inhibition, at one concentration (the size of the read-out at that concentration, not a potency): 40%
Estimate against measurement, compound 4: no gap at the digits printed; measured number inside the range.
By their numbers in this assay, from the lowest: compounds 1, 2, 3 and 4 (each within the scatter of the next).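

The earlier steps shown here swapped one group for another, whereas this one puts a fluoro group on an aromatic carbon that carried only hydrogen, ortho to a large group and meta to the existing fluoro group. In this assay this addition gave no change at the digits printed from compound 2 to compound 4 (within the scatter) and so extends the flat record to a third kind of site on the shared core. The ring can therefore carry a second fluoro group here without a change that this single-concentration read-out can separate from the scatter. No measurement given here explains this result.

What the compounds shown leave open is whether anything larger than fluoro at this position, such as a methoxy group, an amine or a carboxylic acid, would move this assay beyond the scatter. Since this read-out is not a potency, they also leave open whether compound 2 and compound 4 differ in potency.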